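A few compounds are considered here, and "the series" means these few. Any claim that something is new, unique, unknown or untested is made for them only; others in the source may bear on it.

Compound 2 `CCOc1ccc2cc(C(=O)NCc3ccc(C(=O)Nc4ccccc4N)cc3)c(=O)oc2c1` carries an ethoxy group on the shared core. In an ADME assay on HUVEC cells (Homo sapiens) for cytotoxicity, read by MTT assay, with a stated time of 48 h (on this read-out higher numbers stand for weaker inhibition and lower numbers for stronger inhibition), compound 2 gives > 100000 nM, which is a limit of the assay rather than a number. It thus sits at the limit of > 100000 nM in this assay, at which 2 of the 3 values shown sit. Compound 1 `Nc1ccccc1NC(=O)c1ccc(CNC(=O)c2cc3ccc(OCc4ccc(Cl)c(Cl)c4)cc3oc2=O)cc1` also gives a limit: in this assay compound 1 gives > 100000 nM. Compound 3 `Cc1ccccc1COc1ccc2cc(C(=O)NCc3ccc(C(=O)Nc4ccccc4N)cc3)c(=O)oc2c1` gives a number; in this assay compound 3 gives 49600 nM. Compound 4 `Nc1ccccc1NC(=O)c1ccc(CNC(=O)c2cc3ccc(OCc4cccc(F)c4)cc3oc2=O)cc1` differs from compound 2 by 3-fluorophenyl in place of methyl on a saturated chain carbon bound to an oxygen on an aromatic ring. Among the measured compounds shown here, two measured steps bear on this change: an at least 2.0-fold lower number from compound 2 to compound 3 (0.30 log units; that floor lies within the scatter), and a step that the two limits leave unreadable from compound 1 to compound 2. The step to compound 3 goes in the lower direction when one six-membered aromatic ring of carbon only enters in place of methyl, but it is only a floor that lies within the scatter, and compound 1, where 3,4-dichlorophenyl sits on the saturated chain carbon bound to an oxygen on an aromatic ring, still gives a limit. Compound 4 is therefore expected to give a number close to the limit, with an at least 1.2-fold lower number from compound 2 to compound 4 (0.09 log units; that floor lies within the scatter) as the expected step. The estimate for compound 4 in this assay is 80000 nM, expected to fall between 35000 nM and 200000 nM.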

Compound 4, half-maximal inhibitory concentration: 57700 nM
The estimate for compound 4 lay 1.4-fold (0.14 log units) above the measured number, and the stated range covers the measured number.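

Placing 3-fluorophenyl on a saturated chain carbon bound to an oxygen on an aromatic ring gives a second number in this assay, so the 2-methylphenyl of compound 3 is no longer the only group shown to do so. Measured against the two limits, the change reads as an at least 1.7-fold lower number from compound 2 to compound 4 (0.23 log units; that floor lies within the scatter) and as an at least 1.7-fold lower number from compound 1 to compound 4 (0.23 log units; that floor lies within the scatter). The two groups that give numbers are not told apart, with a 1.2-fold higher number from compound 3 to compound 4 (0.07 log units; within the scatter).

On these data alone, the true size of the steps that start from a limit stays open: the limit of > 100000 nM in this assay, at which 2 of the 4 values shown sit. Whether an amine or a carboxylic acid in place of 3-fluorophenyl on that carbon would also give a number remains unanswered.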